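The source may hold more compounds than are shown below. What is called first, only, known or untested is meant among the compounds shown, and "the series" means these compounds.

Measured in a functional assay on SiHa cells (Homo sapiens) for inhibition; a lower number here means a stronger inhibitor, a higher number a weaker inhibitor:
Compound 1 `COc1cc(/C=C/C(=O)c2cccc(NC(=O)c3ccc(Cl)cc3)c2)ccc1O`: 2.3 ug/mL
Compound 2 `COc1cc(/C=C/C(=O)c2cccc(NC(=O)C(C)C)c2)ccc1O`: 5.96 ug/mL

Of the two measured compounds, compound 2 has the higher number, 5.96 ug/mL. Compound 3 `COc1cc(/C=C/C(=O)c2cccc(NC(C)=O)c2)ccc1O` departs from it by one change: methyl in place of isopropyl on a carbonyl carbon. For the measured compounds named here, only one measured step bears on this, a 2.6-fold higher number from compound 1 to compound 2 (0.41 log units; beyond the scatter), made on that same carbonyl carbon. With this single modest step as a guide, a small further rise in this assay is expected, possibly not beyond the scatter. The expected step is a 1.3-fold higher number from compound 2 to compound 3 (0.10 log units; within the scatter). The estimate for compound 3 is 7.5 ug/mL, with an expected range from 3.5 ug/mL to 16 ug/mL.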

Compound 3, half-maximal inhibitory concentration: 15.8 ug/mL
Beside the measured number, compound 3's estimate is 2.1-fold (0.32 log units) below it; the range from low to high includes it.
By their numbers in this assay, from the lowest: compound 1; then compound 2; then compound 3.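

In this assay, for the compounds shown here, methyl in place of isopropyl on this carbonyl carbon gives a 2.7-fold higher number from compound 2 to compound 3 (0.42 log units; beyond the scatter) and shows that the number goes on rising past isopropyl, with no compound going against that order. Taken from 4-chlorophenyl to methyl, the same position spans a 6.9-fold higher number from compound 1 to compound 3 (0.84 log units; beyond the scatter) and so separates all three compounds beyond the scatter. Nothing shown accounts for this order.

Still open, going by these compounds, is whether an unsubstituted phenyl keeps the low number of compound 1, or whether the chlorine matters. A longer straight chain or an amine on this carbonyl carbon also remains to be placed in the order.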